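A few compounds are considered here, and "the series" means these few. Any claim that something is new, unique, unknown or untested is made for them only; others in the source may bear on it.

Measured compounds:
compound 1, `O=C(C(Nc1ccccc1)c1ccc(C(F)(F)F)cc1)N1CCCC1c1ccccc1`: 60 nM
compound 2, `O=C(C(Nc1ccccc1F)c1ccc(C(F)(F)F)cc1)N1CCCC1c1ccc(F)cc1`: 37 nM

Both values come from an assay on HEK293 cells for antagonist activity at transient receptor potential M8 protein (Canis lupus familiaris), read by fluorescence and calcium flux, with a stated time of 5 min; on this read-out higher numbers stand for weaker inhibition and lower numbers for stronger inhibition. Compound 2 gives the lower of the two numbers, yet the gap to compound 1 lies within the usual scatter of repeated measurements, so the two compounds cannot be separated on this read-out. Among the compounds with values here, no pair of measured compounds differing in a single place is available; compound 1 and compound 2 differ from each other in more than one place, so no single structural change has a measured step attached to it.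

Compound 3, `O=C(C(Nc1ccccc1F)c1ccc(C(F)(F)F)cc1)N1CCCC1c1ccncc1`, has not been measured. Relative to compound 2 the change is pyridin-4-yl in place of 4-fluorophenyl on a saturated ring carbon, sitting on a saturated ring carbon of a five-membered non-aromatic ring with 1 nitrogen. Nothing measured in the series bears directly on this exchange, so the expectation rests on the general behaviour of such aromatic swaps. A step toward a higher number, modestly beyond the scatter, is expected, a 2.7-fold higher number from compound 2 to compound 3 (0.43 log units; beyond the scatter). For compound 3 the estimate in this assay is 100 nM, with an expected range from 35 nM to 300 nM.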

Compound 3, half-maximal inhibitory concentration: 19 nM
Compound 3: the middle estimate sits 5.3-fold (0.72 log units) above what was measured; measured number below the stated range.
By their numbers in this assay, from the lowest: compounds 3, 2 and 1 (each within the scatter of the next, the first and the last beyond it).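

In this assay, within the data shown here, the exchange of 4-fluorophenyl for pyridin-4-yl on a saturated ring carbon gives a 1.9-fold lower number from compound 2 to compound 3 (0.29 log units; within the scatter) and is the first single-place step. This position therefore accepts an aromatic ring with 1 hetero atom and 1 hydrogen-bond acceptor in place of a carbon-only aromatic ring bearing fluorine, with no difference beyond the scatter of repeated measurements; the two compounds cannot be separated on this read-out. Nothing at hand accounts for this tolerance, so the result stands as an observation on compounds 2 and 3 alone.

The compounds shown leave open whether the location of the ring nitrogen matters, which pyridin-3-yl or pyridin-2-yl on the same carbon could address, and whether the position also accepts a non-aromatic group such as morpholine or a group carrying a carboxylic acid or an amine. Also open, on these data alone, is what the separate changes between compound 1 and compound 2 contribute, since those two compounds differ in more than one place and neither change has a step of its own.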